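Side-chain branching carried from one core to another

The source may hold more compounds than are shown below. What is called first, only, known or untested is meant among the compounds shown, and "the series" means these compounds.

Compound 1 `CC(C)C(NC(=O)NO)C(=O)NC1CCCC1` stands on one core; in a functional assay on HEp-2 cells (Homo sapiens) for inhibition (a lower number here means a stronger inhibitor, a higher number a weaker inhibitor), compound 1 gives 33400 nM. Compound 3 `CC(C)C(NC(=O)n1nnc2ccccc21)C(=O)NC1CCCCC1` and compound 2 `CCC(C)C(NC(=O)n1nnc2ccccc21)C(=O)NC1CCCCC1` share a second core; in this assay compound 3 gives 60000 nM and compound 2 gives 57900 nM. How the core of compound 1 differs from the core of compound 3 is not broken down here; the values of compound 1 and compound 3 sit within the usual scatter of each other, as do those of compound 1 and compound 2.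

Within the second core the single counted change is methyl in place of hydrogen on a saturated chain carbon, three bonds along the chain from an amide-type nitrogen and a carbonyl carbon, and it made a step of a 1.0-fold lower number from compound 3 to compound 2 (0.02 log units; within the scatter). Compound 4 `CCC(C)C(NC(=O)NO)C(=O)NC1CCCC1` is the not yet measured partner of compound 1 carrying the same change, (methyl in place of hydrogen on a saturated chain carbon, three bonds along the chain from an amide-type nitrogen and a carbonyl carbon), at a place described in the same words for both pairs.

Because that change made a step of a 1.0-fold lower number from compound 3 to compound 2 (0.02 log units; within the scatter) on the second core, the step expected on the first core in this assay is a 1.0-fold lower number from compound 1 to compound 4 (0.01 log units; within the scatter). Compound 4 is therefore estimated at 33000 nM in this assay. Compound 4 is expected to fall between 15000 nM and 75000 nM.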

Compound 4, half-maximal inhibitory concentration: > 100000 nM
Compound 4 was reported as a limit; the forecaster's own chance of this, stated with the estimate: 10%; at least 3.0-fold (0.48 log units) between middle value and limit.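

On the core of compound 1, the change from isopropyl to sec-butyl gives an at least 2.9-fold higher number from compound 1 to compound 4 (0.47 log units; beyond the scatter), so in this assay this change did not carry over from one core to the other: the same change on two cores in this assay, a 1.0-fold lower number (0.02 log units; within the scatter) from compound 3 to compound 2 and an at least 2.9-fold higher number (0.47 log units; beyond the scatter) from compound 1 to compound 4, at least 3.1-fold (0.49 log units) apart, beyond the scatter of two such steps

Compound 4 is reported only as a limit of the assay, > 100000 nM: the limit of > 100000 nM in this assay, at which 1 of the 4 values shown sits.

The comparison rests on a single pair on each core, so the full size of the step on the core of compound 1 remains unknown, and the data give neither a reason for the gap between the cores nor a rule for other side chains.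

Still open, as far as these compounds go, is whether a longer chain such as n-pentyl, or a chain carrying a hydroxyl group or an amine, at the same place would also separate the two cores. Also open, from the compounds shown here alone, is which part of the core of compound 1, set against the core of compound 3, goes with the different outcome.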